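Amide reversal at the end of the cytotoxicity series

A few compounds are considered here, and "the series" means these few. Any claim that something is new, unique, unknown or untested is made for them only; others in the source may bear on it.

In a functional assay on Huh-5-2 cells (Homo sapiens), read by MTT assay (on this read-out lower numbers stand for higher toxicity in this test and higher numbers for lower toxicity in this test), compound 1 `O=C(O)c1ccc(-c2ccc(Cl)cc2)c(COc2ccc(-c3nc4cc(C(=O)O)ccc4n3C3CCCCC3)cc2)c1` gives only a limit, > 50000 nM. Compound 2 `CN(C)C(=O)c1ccc(-c2ccc(Cl)cc2)c(COc2ccc(-c3nc4cc(C(=O)O)ccc4n3C3CCCCC3)cc2)c1` gives 28000 nM and compound 3 `CN(C)C(=O)c1ccc(-c2ccc(Cl)cc2)c(COc2ccc(-c3nc4cc(C(=O)O)ccc4n3C3CCCCC3)c(F)c2)c1` gives 26000 nM, so compound 3 stands level with compound 2, within the scatter. The change to compound 4 `CC(=O)N(C)c1ccc(-c2ccc(Cl)cc2)c(COc2ccc(-c3nc4cc(C(=O)O)ccc4n3C3CCCCC3)c(F)c2)c1` is acetyl(methyl)amino in place of dimethylcarbamoyl on an aromatic carbon, para to a 4-chlorophenyl group. The measured steps that bear on it are an at least 1.7-fold lower number from compound 1 to compound 2 (0.25 log units; that floor lies within the scatter), which involves the same carbonyl group, and a 1.1-fold lower number from compound 2 to compound 3 (0.03 log units; within the scatter). Neither shows a move beyond the scatter, so no step beyond the scatter is expected in this assay. The expected change is a 1.0-fold lower number from compound 3 to compound 4 (0.02 log units; within the scatter). For compound 4 the estimate is 25000 nM, with an expected range of 12000 nM to 50000 nM.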

Compound 4, half-maximal cytotoxic concentration: 26000 nM
Beside the measured number, compound 4's estimate is 1.0-fold (0.02 log units) below it; the range from low to high includes it.
By their numbers in this assay, from the lowest: compounds 3, 4 and 2 (each within the scatter of the next). At a limit, above all of these: compound 1.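

At this position, para to a 4-chlorophenyl group, reversing the amide in this assay gives no change at the digits printed from compound 3 to compound 4 (within the scatter). The earlier steps shown here changed what sits on the carbonyl or added fluoro, whereas this one keeps the same atoms, joined differently, and so tests the direction of the amide itself. That direction makes no readable difference in this assay for this pair.

From the compounds shown here alone, whether a primary amine or a longer chain at this position would move the number remains open. Compound 1 stands only as a limit, so the full size of its step stays unread: the limit of > 50000 nM in this assay, at which 1 of the 4 values shown sits.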